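Open-chain variants at the amidine carbon of the shared core

The source may hold more compounds than are shown below. What is called first, only, known or untested is meant among the compounds shown, and "the series" means these compounds.

Measured so far in an assay on CHO cells for inhibition of Amine oxidase [copper-containing] 3 (Homo sapiens), read by spectrophotometry, with stated times of 30 min and 1 h; on this read-out lower numbers stand for stronger inhibition and higher numbers for weaker inhibition:
compound 1 `CC(=O)Nc1nc(CCc2ccc(NC3=NCCN3)cc2)cs1` gives 3000 nM
compound 2 `CC(=O)Nc1nc(CCc2ccc(NC=N)cc2)cs1` gives 730 nM
compound 3 `CCNC(=N)Nc1ccc(CCc2csc(NC(C)=O)n2)cc1` gives 680 nM

Compound 3 has the lowest number of the three, but its gap to compound 2 is within the scatter, so the two cannot be ordered; only compound 1 stands apart, with the step of a 4.4-fold lower number from compound 1 to compound 3 (0.64 log units; beyond the scatter) beyond the scatter. The related step of a 4.1-fold lower number from compound 1 to compound 2 (0.61 log units; beyond the scatter) points the same way.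

Compound 4 `CC(=O)Nc1nc(CCc2ccc(NC(=N)N(C)C)cc2)cs1` is not yet measured. It differs from compound 3 in one place: dimethylamino in place of ethylamino on a carbon with a double bond to nitrogen, on a carbon with a double bond to nitrogen whose other neighbours are: nitrogen on an aromatic ring. The step that bears on it is a 1.1-fold lower number from compound 2 to compound 3 (0.03 log units; within the scatter), which shows that adding ethylamino at this carbon left this assay unchanged within the scatter. On that basis no step beyond the scatter is expected in this assay; the estimated step of a 1.3-fold higher number from compound 3 to compound 4 (0.12 log units; within the scatter) is set close to zero. Compound 4 is expected at 900 nM, with a range from 300 nM to 2700 nM.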

Compound 4, half-maximal inhibitory concentration: > 100000 nM
Compound 4: a limit, no number; the forecaster's own chance of this, stated with the estimate: 5%; middle value at least 110-fold (2.04 log units) from the limit.
By their numbers in this assay, from the lowest: compounds 3 and 2 (each within the scatter of the next); then compound 1. At a limit, above all of these: compound 4.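

In this assay, the carbon with a double bond to nitrogen proves sensitive to the kind of group it carries, not only to its size: dimethylamino in place of ethylamino gives an at least 140-fold higher number from compound 3 to compound 4 (2.16 log units; beyond the scatter), although the two compounds have the same atoms, joined differently, and the two groups differ in counting 0 against 1 hydrogen-bond donor. Adding ethylamino in place of hydrogen left the number unchanged within the scatter, whereas dimethylamino in place of hydrogen gives an at least 130-fold higher number from compound 2 to compound 4 (2.13 log units; beyond the scatter), and the open-chain group of compound 4 in place of the ring of compound 1 gives an at least 33-fold higher number from compound 1 to compound 4 (1.52 log units; beyond the scatter). Compound 4 stands at a limit of the assay, so these steps have no upper end: the limit of > 100000 nM in this assay, at which 1 of the 4 values shown sits.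

The compounds shown do not tell whether the hydrogen-bond donor count or some other feature of dimethylamino underlies the step. On these data alone, it remains open whether methylamino or propylamino at this carbon would stay with compound 3 or go with compound 4.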